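Replacing a benzylamino group by a seven-membered cyclic amine

A few compounds are considered here, and "the series" means these few. Any claim that something is new, unique, unknown or untested is made for them only; others in the source may bear on it.

Measured compounds:
compound 1, `CC(C(=O)NCc1ccc(C(F)(F)F)nc1NCc1ccc(Cl)cc1)c1ccc(NS(C)(=O)=O)c(F)c1`, 65.7 nM
compound 2, `C[C@H](C(=O)NCc1ccc(C(F)(F)F)nc1N1CCC(c2ccccc2)CC1)c1ccc(NS(C)(=O)=O)c(F)c1`, 0.3 nM
compound 3, `CC(C(=O)NCc1ccc(C(F)(F)F)nc1N1CCC2(CC1)CC(C(C)(C)C)=NO2)c1ccc(NS(C)(=O)=O)c(F)c1`, 3.8 nM

All three share one core and differ only in the group attached next to the ring nitrogen. In a functional assay on CHO-K1 cells for antagonist activity at transient receptor potential cation channel subfamily V member 1 (Homo sapiens), read by FLIPR (on this read-out lower numbers stand for stronger inhibition and higher numbers for weaker inhibition), compound 1 gives the highest of the three numbers. Compound 3 stands nearest to it, and compound 2 furthest away; in both cases the gap lies beyond the usual scatter, so compound 1 is the weakest inhibitor of the three.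

Compound 4, `CC(C(=O)NCc1ccc(C(F)(F)F)nc1N1CCCCCC1)c1ccc(NS(C)(=O)=O)c(F)c1`, has not yet been measured. It differs from compound 1 in one place: azepan-1-yl in place of (4-chlorobenzyl)amino on an aromatic carbon. Both compounds with a ring-bound tertiary amine, compound 2 and compound 3, give far lower numbers than compound 1, whose group carries a benzylamino link. Compound 4 has such a ring-bound amine as well, but without the extra aromatic ring or the spiro ring of compound 2 and compound 3.

Going by the values given here, only two examples support this trend, so the estimate is uncertain. For compound 4 a clearly lower number than for compound 1 is expected, a step of a 6.6-fold lower number from compound 1 to compound 4 (0.82 log units; beyond the scatter). In this assay compound 4 is estimated at 10 nM, within a range from 2 nM to 60 nM.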

Compound 4, inhibition constant: 0.8 nM
For compound 4 the middle estimate is 13-fold (1.10 log units) above the measured one; the whole stated range lies above it.
By their numbers in this assay, from the lowest: compound 2; then compound 4; then compound 3; then compound 1.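

Going by these compounds alone, measured in this assay, azepan-1-yl in place of (4-chlorobenzyl)amino on an aromatic carbon next to the ring nitrogen gives an 82-fold lower number from compound 1 to compound 4 (1.91 log units; beyond the scatter) and, as the only pair here that differs in one place, this isolates the effect of the group at this position from any other change in the structure. Compound 4 carries no six-membered aromatic ring in this group, no chlorine and no hydrogen-bond donor, and it has fewer heavy atoms, so strong inhibition at this position requires none of these features of the (4-chlorobenzyl)amino group. No measurement shown explains the size of this step.

Because several features change together in this single swap, the pair cannot show which of them accounts for the step; a methyl(4-chlorobenzyl)amino group, which keeps the aromatic ring but has no amine hydrogen, and a plain benzylamino group, which lacks only the chlorine, would help to separate them. From the compounds shown here alone, whether the seven-membered ring itself matters also remains open, a question that smaller cyclic amines such as pyrrolidin-1-yl and piperidin-1-yl at the same position could address.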